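Swapping the anilino group for a fused bicyclic amine

The compounds below may be only part of what the source reports. "The series", "measured", "known", "first", "only" and "open" are said of these compounds alone.

Compound 3: `Cn1ccc2cc(-c3ccc4oc(Nc5ccccc5)nc4c3)ccc21` — 48 nM
Compound 2: `Cn1ncc2c(-c3ccc4oc(NC5CCCCC5)nc4c3)cccc21` — 52 nM
Compound 1: `c1cc2c(ccn2C2COC2)cc1-c1ccc2oc(NC3CCCCC3)nc2c1` — 579 nM

Of the compounds shown here, three sharing a core have been tested in an assay on HEK293 cells for inhibition of Fatty-acid amide hydrolase 1 (Homo sapiens), read by fluorescence; a lower number here means a stronger inhibitor, a higher number a weaker inhibitor. Compound 3 gives 48 nM, the lowest of the three numbers. Compound 2 gives 52 nM, which sits within the scatter of compound 3, so the two cannot be told apart. Compound 1 gives 579 nM, a clearly weaker result than compound 3, beyond the scatter.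

Compound 4, `Cn1ccc2cc(-c3ccc4oc(N5Cc6ccncc6C5)nc4c3)ccc21`, has not yet been measured. It differs from compound 3 in one place: a group of 9 heavy atoms (7 carbon, 2 nitrogen; one five-membered non-aromatic ring with 1 hetero atom, one six-membered aromatic ring with 1 hetero atom) in place of a group of 7 heavy atoms (6 carbon, 1 nitrogen; one six-membered aromatic ring of carbon only), on an aromatic carbon The group that leaves carries a hydrogen-bond donor; the group that enters carries none.

For the measured compounds named here, no measured pair shows this particular change, so the expectation rests on the structural change alone. The step of a 3.1-fold higher number from compound 3 to compound 4 (0.49 log units; beyond the scatter) is expected to be a modest weakening, somewhat beyond the scatter but far smaller than the gap to compound 1. Compound 4 is therefore estimated at 150 nM, with a plausible range from 30 nM to 800 nM.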

Compound 4, half-maximal inhibitory concentration: 121 nM
The estimate for compound 4 lay 1.2-fold (0.09 log units) above the measured number, within the range that was stated.
By their numbers in this assay, from the lowest: compounds 3 and 2 (each within the scatter of the next); then compound 4; then compound 1.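

Replacing the anilino group on this aromatic carbon with the larger fused group gives a 2.5-fold higher number from compound 3 to compound 4 (0.40 log units; beyond the scatter) in this assay, a modest weakening rather than a complete loss of inhibition. Compound 4 has no hydrogen-bond donor in this group and still gives 121 nM, so the donor of the anilino group is not required for inhibition at this level. No measurement shown here explains why the number rises.

This single change alters the donor count and the rings together, so their contributions cannot be separated. Going by these compounds, a benzylamino group, which keeps a donor, and a plain piperidine, which has none, would help to pull them apart, and it also remains open whether the same swap would have a similar effect with a different group elsewhere on the shared core.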